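The compounds below may be only part of what the source reports. "The series", "measured", "known", "first", "only" and "open" are said of these compounds alone.

Going by the values given here, compound 2 `CC(C)(C)/[N+]([O-])=C/c1cn(-c2ccccc2)nn1` is the only member of the pair with a number in a functional assay on A549 cells (Homo sapiens) for inhibition, read by MTT assay, with a stated time of 24 h; on this read-out lower numbers stand for stronger inhibition and higher numbers for weaker inhibition; in this assay compound 2 gives 17400 nM. Compound 1 `[O-]/[N+](=C\c1cn(-c2ccccc2)nn1)Cc1ccccc1` reaches only a limit of this assay, > 100000 nM, which is the limit of > 100000 nM in this assay, at which 1 of the 2 values shown sits. Among the compounds with values here, the single measured step, an at least 5.7-fold lower number from compound 1 to compound 2 (0.75 log units; beyond the scatter), concerns the substituent on the double-bonded nitrogen alone and leaves the rest of the shared core untouched.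

Compound 3 `CC(C)(C)/[N+]([O-])=C/c1cn(-c2ccc(C(F)(F)F)cc2)nn1` keeps the tert-butyl of compound 2 and changes the six-membered aromatic ring of carbon only: trifluoromethyl in place of hydrogen on an aromatic carbon, the new group sitting para to a large group. Within the data shown here, no measured step touches this ring, so the one step known gives no direction for the change; the series so far holds no comparison between an unsubstituted and a substituted ring of this kind.

For compound 3 in this assay no step beyond the usual scatter is expected: a 1.2-fold lower number from compound 2 to compound 3 (0.06 log units; within the scatter). Compound 3 is therefore estimated at 15000 nM, with a range from 5000 nM to 45000 nM.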

Compound 3, half-maximal inhibitory concentration: 43600 nM
Compound 3: middle estimate off by 2.9-fold (0.46 log units), on the low side; low and high end bracket the measured number.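

In this assay the six-membered aromatic ring of carbon only now has a measured step of its own: trifluoromethyl in place of hydrogen on an aromatic carbon, para to a large group, gives a 2.5-fold higher number from compound 2 to compound 3 (0.40 log units; beyond the scatter) and thus moves the read-out towards weaker inhibition. Going by these compounds alone, the only earlier step lay on the substituent of the double-bonded nitrogen, so this is the first sign that, with the tert-butyl held fixed, a change on this ring can shift the number beyond the scatter. Nothing at hand gives a measured property that would account for this step.

Going by these compounds, whether this direction belongs to trifluoromethyl alone or extends to other groups at this position, such as a methoxy group, a fluorine atom or an amine, stays open. Also open, on these data alone, is whether the same ring change would read the same way with benzyl in place of tert-butyl on the double-bonded nitrogen.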